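Swapping the benzyl ring substituent on a para-benzyloxyphenyl oxadiazolone

The source may hold more compounds than are shown below. What is called first, only, known or untested is meant among the compounds shown, and "the series" means these compounds.

Measured compounds:
- compound 1, `Cc1ccc(COc2ccc(-c3nn(CCC#N)c(=O)o3)cc2)cc1`, in an assay for inhibition of Amine oxidase [flavin-containing] A (Rattus norvegicus) (a lower number here means a stronger inhibitor, a higher number a weaker inhibitor), compound 1 gives 25000 nM
- compound 2, `N#CCCn1nc(-c2ccc(OCc3cccc(Cl)c3)cc2)oc1=O`, in this assay compound 2 gives 7400 nM

Compound 2 holds the lowest of the two numbers, and the gap between the two is a 3.4-fold lower number from compound 1 to compound 2 (0.53 log units; beyond the scatter), so the two are told apart beyond the scatter. Both share the same core; they differ only in the ring that sits on a saturated chain carbon bound to an oxygen on an aromatic ring.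

Compound 3, `N#CCCn1nc(-c2ccc(OCc3ccc([N+](=O)[O-])cc3)cc2)oc1=O`, is not yet measured. It differs from compound 2 by 4-nitrophenyl in place of 3-chlorophenyl on a saturated chain carbon bound to an oxygen on an aromatic ring. Among the compounds with values here, the one measured step that touches this same place, a 3.4-fold lower number from compound 1 to compound 2 (0.53 log units; beyond the scatter), was modest, and it compared two groups that are both absent from compound 3. Nothing measured here separates a 4-nitrophenyl group from a 3-chlorophenyl group, so the data give no direction for the change. A step near the scatter, in either direction, is therefore expected for compound 3, that is a 1.1-fold higher number from compound 2 to compound 3 (0.03 log units; within the scatter). The estimated value for compound 3 in this assay is 8000 nM, with a range from 2000 nM to 30000 nM.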

Compound 3, half-maximal inhibitory concentration: 11000 nM
Estimate against measurement, compound 3: 1.4-fold (0.14 log units) below; low and high end bracket the measured number.
By their numbers in this assay, from the lowest: compounds 2 and 3 (each within the scatter of the next); then compound 1.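

In this assay the step of a 1.5-fold higher number from compound 2 to compound 3 (0.17 log units; within the scatter) lies within the scatter, so at this place, on a saturated chain carbon bound to an oxygen on an aromatic ring, the data do not tell 4-nitrophenyl from 3-chlorophenyl, even though the two groups share little beyond the ring itself. The other new step, a 2.3-fold lower number from compound 1 to compound 3 (0.36 log units; beyond the scatter) with nitro in place of methyl on an aromatic carbon, lies beyond the scatter, so compound 1 with its 4-methylphenyl group now stands apart from both other compounds, and neither of them goes against this. The data offer no measured explanation for either result.

The 3-chlorophenyl and 4-nitrophenyl groups differ both in the substituent and in where it sits on the ring, so a 4-chlorophenyl group would be needed to separate those two changes, and a plain phenyl ring would show whether any substituent matters at all. From the compounds shown here alone, it also remains open how an amine or a carboxylic acid on this ring would compare, and whether a longer chain in place of the nitrile-bearing chain on the shared core would shift the numbers.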